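A few compounds are considered here, and "the series" means these few. Any claim that something is new, unique, unknown or untested is made for them only; others in the source may bear on it.

Three compounds have been measured in an ADME assay on Huh-7 cells (Homo sapiens) for cytotoxicity, with a stated time of 3 days; on this read-out lower numbers stand for higher toxicity in this test and higher numbers for lower toxicity in this test:

- compound 1, `COc1ccccc1NC(=O)c1c(NO)cc(-c2ccccc2)oc1=O`, > 20000 nM
- compound 2, `O=C(Nc1ccc(Cl)cc1)c1c(NCCO)cc(-c2cccc(Br)c2)oc1=O`, 17000 nM
- compound 3, `O=C(Nc1ccc(Cl)cc1)c1c(NCCO)cc(-c2ccc(Br)cc2)oc1=O`, > 20000 nM

Compound 3 stands at the limit of > 20000 nM in this assay, at which 2 of the 3 values shown sit; in this assay compound 3 gives > 20000 nM, which is a limit and not a number. Compound 1 likewise gives only a limit, > 20000 nM. Going by the values given here, compound 2 is the one compound with a number, 17000 nM, and the one measured step, an at least 1.1-fold higher number from compound 2 to compound 3 (0.07 log units; that floor lies within the scatter), lies within the scatter.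

Compound 4, `CCOc1ccccc1NC(=O)c1c(NCCO)cc(-c2ccc(Br)cc2)oc1=O`, differs from compound 3 by 2-ethoxyphenyl in place of 4-chlorophenyl on an amide-type nitrogen. Among the compounds with values here, no measured step touches this position: the only step, an at least 1.1-fold higher number from compound 2 to compound 3 (0.07 log units; that floor lies within the scatter), concerns the aryl on the ring and was small. Compound 1, which carries a 2-methoxyphenyl on the amide nitrogen, sits at the same limit as compound 3, so the shown values give no sign that this part of the molecule moves the read-out. Compound 4 is therefore expected to remain at or near the limit, with an estimated 25000 nM, ranging from 10000 nM to 60000 nM. The expected step that the limit leaves unreadable from compound 3 to compound 4 is thus none beyond the scatter.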

Compound 4, half-maximal cytotoxic concentration: > 20000 nM
Compound 4: no number, only a limit (the forecaster's own chance of this, stated with the estimate: 75%); the middle value does not contradict the limit.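

In this assay, going by these compounds alone, compound 3 and compound 4 each give only a limit, so no step between them can be read: the limit of > 20000 nM in this assay, at which 3 of the 4 values shown sit. The compounds shown leave open whether 2-ethoxyphenyl in place of 4-chlorophenyl on an amide-type nitrogen changes this read-out at all.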